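The source may report more compounds than this note shows. Statements on the series, on what has been measured and on what is new or still open speak of the compounds shown alone.

Measured in an ADME assay on LLC-PK1 cells (Sus scrofa) for permeability; a higher number here means that the compound crosses the layer faster, a lower number that the compound crosses the layer more slowly:
- Compound 1 `CCn1c(-c2ccc(C(F)(F)F)nc2)nc2c(O[C@H]3CCN(C(=O)C4CCOC4)C3)ncnc21`: 27 10^-6 cm/s
- Compound 2 `CCn1c(-c2cnc(C)nc2)nc2c(N[C@H]3CCN(C(=O)[C@H]4C[C@@H](OC)C4)C3)ncnc21`: 10 10^-6 cm/s

For the measured compounds named here, of these two numbers, the one for compound 2 is the lower, and the gap to compound 1 lies beyond the scatter. These two compounds differ in more than one place, so their gap does not gauge any single change.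

Compound 3 `CCn1c(-c2cnc(C)nc2)nc2c(N[C@H]3CCN(C(=O)C4CC4)C3)ncnc21` has cyclopropyl in place of 3-methoxycyclobutyl on a carbonyl carbon. Going by the values given here, no measured pair shows this change, so in this assay no move beyond the scatter is expected, with a slight upward lean. The expected change is a 1.4-fold higher number from compound 2 to compound 3 (0.15 log units; within the scatter). For compound 3 the estimated value is 14 10^-6 cm/s, with an expected range of 7 10^-6 cm/s to 28 10^-6 cm/s.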

Compound 3, apparent permeability: 22 10^-6 cm/s
Compound 3: the middle estimate sits 1.6-fold (0.20 log units) below what was measured; measured number inside the range.
By their numbers in this assay, from the lowest: compound 2; then compounds 3 and 1 (each within the scatter of the next).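

In this assay, the group on this carbonyl carbon proves able to move the number by itself: cyclopropyl in place of 3-methoxycyclobutyl gives a 2.2-fold higher number from compound 2 to compound 3 (0.34 log units; beyond the scatter) with the rest of the structure unchanged. For the compounds shown here, this is the first comparison here that isolates a single change, though it alters ring size and removes the methoxy group together. Nothing available explains the rise.

An unsubstituted cyclobutyl or a dimethylamino group at this place would help separate those two parts. Going by these compounds, whether the step carries over to the core of compound 1 also remains open.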